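Amide substituent swaps on the shared core

The source may hold more compounds than are shown below. What is called first, only, known or untested is meant among the compounds shown, and "the series" means these compounds.

Compound 1 `Cn1cncc1CN1CC(N(CC2CCN(C(=O)CNC(=O)OC(C)(C)C)CC2)S(=O)(=O)c2ccccn2)Cc2cc(C#N)ccc21` was run in an ADME assay on Caco-2 cells (Homo sapiens) for permeability, in the apical to basolateral direction (a higher number here means that the compound crosses the layer faster, a lower number that the compound crosses the layer more slowly), where compound 1 gives 0.5 10^-6 cm/s. Compound 2 `CC(C)NC(=O)N1CCC(CN(C2Cc3cc(C#N)ccc3N(Cc3cncn3C)C2)S(=O)(=O)c2ccccn2)CC1` gives 0.6 10^-6 cm/s, and compound 3 `Cn1cncc1CN1CC(N(CC2CCN(C(=O)c3cccs3)CC2)S(=O)(=O)c2ccccn2)Cc2cc(C#N)ccc21` gives 0.5 10^-6 cm/s. Compound 1 is level with compound 3 at the digits printed, together the lowest of the three numbers; compound 2 is furthest, yet a 1.2-fold higher number from compound 1 to compound 2 (0.08 log units; within the scatter) stays within the scatter, as do no change at the digits printed from compound 1 to compound 3 (within the scatter) and a 1.2-fold lower number from compound 2 to compound 3 (0.08 log units; within the scatter). Compound 4 `Cn1cncc1CN1CC(N(CC2CCN(C(=O)N3CCCCC3)CC2)S(=O)(=O)c2ccccn2)Cc2cc(C#N)ccc21` differs from compound 1 by piperidin-1-yl in place of ((tert-butoxycarbonyl)amino)methyl on a carbonyl carbon, again on the carbonyl carbon whose other neighbour is an amide-type nitrogen in a ring. Since all three measured steps change this same carbonyl carbon without leaving the scatter, no step beyond the scatter is expected for compound 4: no change at the digits printed from compound 1 to compound 4 (within the scatter). Compound 4 is estimated at 0.5 10^-6 cm/s, within 0.25 10^-6 cm/s to 1 10^-6 cm/s.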

Compound 4, apparent permeability: 0.6 10^-6 cm/s
Compound 4: middle estimate off by 1.2-fold (0.08 log units), on the low side; the range from low to high includes it.
By their numbers in this assay, from the lowest: compounds 1, 3, 2 and 4 (each within the scatter of the next).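

Piperidin-1-yl brings a six-membered non-aromatic ring with no hydrogen-bond donors or acceptors to this carbonyl carbon, and in this assay every step to it stays within the scatter (a 1.2-fold higher number from compound 1 to compound 4 (0.08 log units; within the scatter); a 1.2-fold higher number from compound 3 to compound 4 (0.08 log units; within the scatter); no change at the digits printed from compound 2 to compound 4 (within the scatter)). The four groups at this place, with or without a ring or hydrogen-bond donors, therefore show no step beyond the scatter. Nothing available gives a reason for this flat result.

From the compounds shown here alone, whether a carboxylic acid or a primary amine on this carbonyl carbon would step beyond the scatter remains open, as does the effect of any change elsewhere on the shared core.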